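The source may hold more compounds than are shown below. What is called first, only, known or untested is meant among the compounds shown, and "the series" means these compounds.

Measured compounds:
Compound 1 `C[Se]/C(=N\C(=O)c1cccs1)NC(=O)c1cccs1`: 1500 nM
Compound 2 `O=C(/N=C(/NC(=O)c1cccs1)[Se]Cc1ccccc1)c1cccs1`: 58100 nM

Going by the values given here, in a functional assay on HepG2 cells (Homo sapiens) for cytotoxicity, read by MTT assay, with a stated time of 72 h (a higher number here means a weaker inhibitor of growth, a lower number a stronger inhibitor of growth), compound 1 gives 1500 nM, and compound 2 gives 58100 nM, the highest of the two numbers so far; its nearest neighbour is compound 1, and the only measured step, a 39-fold higher number from compound 1 to compound 2 (1.59 log units; beyond the scatter), runs between them.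

Compound 3 `CS/C(=N\C(=O)c1cccs1)NC(=O)c1cccs1` has not yet been measured. Relative to compound 2 the change is a group of 2 heavy atoms (1 carbon, 1 sulfur; no ring) in place of a group of 8 heavy atoms (7 carbon, 1 selenium; one six-membered aromatic ring of carbon only), on a carbon with a double bond to nitrogen. Among the compounds with values here, this step is the reverse of the measured one in part, since it removes the phenyl that was added on the saturated chain carbon bound to the selenium atom in a 39-fold higher number from compound 1 to compound 2 (1.59 log units; beyond the scatter), and at the same time exchanges that selenium atom for sulfur, an exchange for which no measured pair exists. Because the phenyl removal alone is covered by a 39-fold higher number from compound 1 to compound 2 (1.59 log units; beyond the scatter), a large fall in this assay is expected, back toward the number of compound 1, with extra uncertainty from the unmeasured selenium-to-sulfur exchange.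

Compound 3 is therefore expected to give about 2500 nM in this assay, within roughly 700 nM to 12000 nM, which means an expected step of a 23-fold lower number from compound 2 to compound 3 (1.37 log units; beyond the scatter).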

Compound 3, concentration for total growth inhibition: > 100000 nM
Compound 3: only a limit was reported (the forecaster's own chance of this, stated with the estimate: 5%); middle value at least 40-fold (1.60 log units) away from the limit.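

In this assay compound 3 is reported only as a limit, not as a number: the limit of > 100000 nM in this assay, at which 1 of the 3 values shown sits. With methylsulfanyl in place of the group of one carbon and one selenium, on a carbon with a double bond to nitrogen, the rest of the core stays the same and the result is an at least 66-fold higher number from compound 1 to compound 3 (1.82 log units; beyond the scatter), so this position responds strongly to the exchange of selenium for sulfur alone, which the earlier phenyl step could not show. The other new comparison gives an at least 1.7-fold higher number from compound 2 to compound 3 (0.23 log units; that floor lies within the scatter); that floor lies within the scatter, and no order of the two compounds can be read from it.

The compounds shown leave open how far the true number of compound 3 lies from its limit, and whether phenyl on the saturated chain carbon would change the number in the same way with sulfur as it does with selenium. They also leave open how a longer chain on the selenium atom, or an amine on this same carbon, would stand against compound 1 in this assay.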